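A few compounds are considered here, and "the series" means these few. Any claim that something is new, unique, unknown or untested is made for them only; others in the source may bear on it.

Compound 1 `CCc1ccc(SCc2ccc(C(=O)Nc3ccccc3N)cc2)cc1`: 3040 nM
Compound 2 `Nc1ccccc1NC(=O)c1ccc(CSc2cccc(F)c2)cc1`: "not determined" (no result reported)

In a functional assay on A549 cells (Homo sapiens) for antiproliferative activity, read by CCK-8 assay, with a stated time of 72 h (a lower number here means a stronger inhibitor, a higher number a weaker inhibitor), compound 1 gives 3040 nM. Compound 2 has no single number, since its entry reads "not determined" (no result reported), so it offers no starting value. Still unmeasured is compound 3 `Nc1ccccc1NC(=O)c1ccc(CSCCc2ccccc2)cc1`. The change is phenethyl in place of 3-fluorophenyl on a sulfur. For the measured compounds named here, with no number for compound 2, the only guide is compound 1 at 3040 nM, so no step beyond the usual scatter, in either direction, is expected in this assay. The expected value for compound 3 is 3000 nM, with an estimated range of 1000 nM to 9000 nM.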

Compound 3, half-maximal inhibitory concentration: 3250 nM
Compound 3: middle estimate off by 1.1-fold (0.03 log units), on the low side, within the range that was stated.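

In this assay, phenethyl in place of 4-ethylphenyl on the sulfur gives a 1.1-fold higher number from compound 1 to compound 3 (0.03 log units; within the scatter), so these two groups cannot be told apart at this position. The step from compound 2 to compound 3 cannot be read, since compound 2 has no number to compare. Nothing available explains why the two groups read alike.

As far as these compounds go, the standing of 3-fluorophenyl at this position remains open. So does whether a quite different group on the same sulfur, such as a chain ending in an amine or a carboxylic acid, would read the same.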